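The compounds below may be only part of what the source reports. "The series", "measured", "known", "first", "only" and "open" are said of these compounds alone.

The measured compounds:
compound 1 `CCCCC/C=C\C/C=C\C/C=C\C=C\C(S)CCCC(=O)O`; in an assay for inhibition of Polyunsaturated fatty acid 5-lipoxygenase (Rattus norvegicus) (on this read-out higher numbers stand for weaker inhibition and lower numbers for stronger inhibition), compound 1 gives 7600 nM.
compound 2 `CCCCC/C=C\C/C=C\C/C=C\C=C\C(CS)CCCC(=O)O`; in this assay compound 2 gives 11000 nM.
compound 3 `CCCCC/C=C\C/C=C\C/C=C\C=C\C(CCCC(=O)O)CC(=O)NO`; in this assay compound 3 gives 190 nM.

Compound 2 has the highest number of the three; compound 1 lies near it, a 1.4-fold higher number from compound 1 to compound 2 (0.16 log units; within the scatter), while compound 3 lies far lower, a 58-fold lower number from compound 2 to compound 3 (1.76 log units; beyond the scatter). Compound 4 `CCCCC/C=C\C/C=C\C/C=C\C=C\C(CCCC(=O)O)NO` differs from compound 2 in one place: hydroxyamino in place of sulfanylmethyl on a saturated chain carbon bound to a double-bonded chain carbon and a saturated chain carbon. Among the compounds with values here, two measured steps bear on this change, each replacing sulfanyl or sulfanylmethyl with a group carrying hydroxycarbamoyl: a 40-fold lower number from compound 1 to compound 3 (1.60 log units; beyond the scatter) and a 58-fold lower number from compound 2 to compound 3 (1.76 log units; beyond the scatter). Hydroxyamino is not hydroxycarbamoyl, and no measured compound carries it, so these steps give a direction rather than a size. A lower number in this assay is expected for compound 4, smaller than either of those steps, a 7.3-fold lower number from compound 2 to compound 4 (0.87 log units; beyond the scatter). Compound 4 is estimated at 1500 nM, within 300 nM to 8000 nM.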

Compound 4, half-maximal inhibitory concentration: 21000 nM
Estimate against measurement, compound 4: 14-fold (1.15 log units) below; measured number outside the range, above it.
By their numbers in this assay, from the lowest: compound 3; then compounds 1, 2 and 4 (each within the scatter of the next, the first and the last beyond it).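

In this assay, hydroxyamino on this saturated chain carbon does not keep the low number of the (hydroxycarbamoyl)methyl group, with a 110-fold higher number from compound 3 to compound 4 (2.04 log units; beyond the scatter) for that exchange. In place of sulfanylmethyl it gives a 1.9-fold higher number from compound 2 to compound 4 (0.28 log units; within the scatter) and so no readable change, while in place of sulfanyl it gives a 2.8-fold higher number from compound 1 to compound 4 (0.44 log units; beyond the scatter) and so a modest loss. Nothing measured here explains these results. The compounds shown leave open whether hydroxycarbamoyl set directly on this carbon, or a carboxylic acid in the same place, would keep the low number of compound 3.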